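The compounds below may be only part of what the source reports. "The series", "measured", "known", "first", "only" and "open" are said of these compounds alone.

Compound 2, `CN(C)Cc1ccc(CNc2nc(N3CCN(C4CCCC4)CC3)c3ncn(CCCN4CCCC4)c3n2)cc1`, is measured in an ADME assay on microsomes from liver (Mus musculus) for metabolic stability, read by LC-MS, with a stated time of 60 min (a higher number here means faster removal of the compound, a lower number slower removal), and gives 8.38 mL.min-1.g-1. Of the three compounds measured, compound 2 has the second highest number: compound 1, `CCN1CCN(CCCn2cnc3c(N4CCN(CC)CC4)ncnc32)CC1`, gives 6.21 mL.min-1.g-1, a value within the scatter of compound 2, while compound 3, `Fc1ccc(CNc2nc(N3CCN(C4CCCC4)CC3)c3ncn(CCCN4CCCC4)c3n2)cc1`, gives 23.1 mL.min-1.g-1, and the step of a 2.8-fold higher number from compound 2 to compound 3 (0.44 log units; beyond the scatter) lies beyond the scatter. That step replaces a group on an aromatic carbon, a part of the molecule untouched here.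

Compound 4, `CCN1CCN(c2nc(NCc3ccc(CN(C)C)cc3)nc3c2ncn3CCCN2CCCC2)CC1`, differs from compound 2 in one place: ethyl in place of cyclopentyl on an amine nitrogen in a ring. Going by the values given here, no measured step changes this group on this nitrogen, so the change cannot be calibrated. Compound 1 carries an ethyl on a ring nitrogen of the same kind, and its value sits within the scatter of compound 2, but compound 1 differs from compound 2 in several other places, so this is only a weak hint. In this assay no step beyond the scatter is expected; compound 4 is estimated at 7.5 mL.min-1.g-1, between 3.5 mL.min-1.g-1 and 16 mL.min-1.g-1, which is the expected step of a 1.1-fold lower number from compound 2 to compound 4 (0.05 log units; within the scatter).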

Compound 4, intrinsic clearance in microsomes: 4.74 mL.min-1.g-1
The estimate for compound 4 lay 1.6-fold (0.20 log units) above the measured number, and the stated range covers the measured number.
By their numbers in this assay, from the lowest: compounds 4, 1 and 2 (each within the scatter of the next); then compound 3.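

Going by these compounds alone, this is the first measured step at this ring nitrogen: in this assay, going from 4-cyclopentylpiperazin-1-yl to 4-ethylpiperazin-1-yl gives a 1.8-fold lower number from compound 2 to compound 4 (0.25 log units; within the scatter) and so stays within what repeat measurements would show. Replacing the cyclopentyl ring with an ethyl group that has no ring therefore leaves no clear mark on this read-out, whereas the change on the aromatic carbon, a 2.8-fold higher number from compound 2 to compound 3 (0.44 log units; beyond the scatter), lies beyond the scatter. No supporting data explain why the number holds here, so this remains a plain observation.

Going by these compounds, whether the same holds for other groups on this nitrogen, such as a benzyl group, a 2-hydroxyethyl chain or an acetyl group, stays open. On these data alone, it is also open whether ethyl in place of cyclopentyl would stay within the scatter with fluoro on the aromatic carbon, as in compound 3.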